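Phenyl for hydrogen on two related cores: solubility

This account rests on a few compounds, and the source may have more. Where it says the series, first, only, none or still open, it means among the compounds named here.

The study compares four compounds sharing a fused two-ring core. Compound 1 `Cc1cc2c(c(N)nn2C)c(=O)[nH]1` is the smallest; compound 2 `Cc1[nH]c(=O)c2c(N)nn(C)c2c1-c1ccccc1` carries a phenyl in place of hydrogen on an aromatic carbon. Compound 3 `Cc1cc2nn(-c3ccccc3)c(N)c2c(=O)[nH]1` has a core that differs from that of compound 1, and the difference between the two cores is not broken down here. Compound 4 `Cc1[nH]c(=O)c2c(N)n(-c3ccccc3)nc2c1-c1ccccc1`, not yet measured, stands to compound 3 as compound 2 stands to compound 1: the change is phenyl in place of hydrogen on an aromatic carbon, and the two place descriptions agree word for word, so it is the same change.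

In a physicochemical assay for solubility, read by HPLC (a higher number here means a more soluble compound, a lower number a less soluble compound), compound 1 gives 1220 ug/mL. Compound 2 gives 2 ug/mL, a step of a 610-fold lower number from compound 1 to compound 2 (2.79 log units; beyond the scatter). Compound 3 gives 69 ug/mL, a lower number than compound 1 and a higher one than compound 2.

Among the measured compounds shown here, for compound 4 the step is expected to be a 350-fold lower number from compound 3 to compound 4 (2.54 log units; beyond the scatter), resting on the single measured instance of this change, a 610-fold lower number from compound 1 to compound 2 (2.79 log units; beyond the scatter). Compound 4 is therefore estimated at 0.2 ug/mL, within 0.03 ug/mL to 2 ug/mL.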

Compound 4, solubility: 7 ug/mL
Compound 4: middle estimate off by 35-fold (1.54 log units), on the low side; the measured number lies above the stated range.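

In this assay the change from hydrogen to phenyl on this aromatic carbon gives a 9.9-fold lower number from compound 3 to compound 4 (0.99 log units; beyond the scatter) on the core of compound 3, against a 610-fold lower number from compound 1 to compound 2 (2.79 log units; beyond the scatter) on the core of compound 1, so the direction carried over from one core to the other while the size did not. With only these two instances, the pair shows that the step cannot be moved between these cores at full size, but it gives no rule for how far the step shrinks or grows on any other core. Nothing given here bears on what sets the two steps apart, and no cause for the difference can be offered.

The compounds shown hold only hydrogen or phenyl on this aromatic carbon, so how a methyl group, an amine or a carboxylic acid in that place would read in this assay on either core stays open. Going by these compounds, whether phenyl in place of hydrogen keeps its direction on a third core also stays open.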